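Ring Shift on a Phenol Ether: Compound 2 to Compound 3

The compounds below may be only part of what the source reports. "The series", "measured", "known", "first", "only" and "open" are said of these compounds alone.

Compound 1 `Cc1cc(Cl)cc(-c2ccnc3cc(CN4C(=O)C5C(C4=O)C5(C)C)sc23)c1C[C@@H]1CNCCO1` gives 25 nM in an assay on RKO cells for inhibition of ubiquitin carboxyl-terminal hydrolase 7 (Homo sapiens), read by a luciferase reporter, with a stated time of 18 h; on this read-out lower numbers stand for an effect already at smaller amounts and higher numbers for an effect only at larger amounts of compound. Compound 2 `Cc1cc(Cl)cc(-c2ccnc3cc(CN4C(=O)C5C(C4=O)C5(C)C)sc23)c1OC1CCCNC1` gives 250 nM in this assay.

Within the data shown here, compound 2 stands at the higher of the two numbers measured so far; its only neighbour is compound 1, and the step of a 10-fold higher number from compound 1 to compound 2 (1.00 log units; beyond the scatter) separates them. Compound 3 `Cc1cc(Cl)cc(-c2ccnc3cc(CN4C(=O)C5C(C4=O)C5(C)C)sc23)c1O[C@@H]1CCNC[C@@H]1C` has not yet been measured. It differs from compound 2 in one place: 3-methylpiperidin-4-yl in place of piperidin-3-yl on an oxygen on an aromatic ring.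

Among the measured compounds shown here, only one measured step exists, and it concerns a different exchange, the one from compound 1 to compound 2, where a 10-fold higher number from compound 1 to compound 2 (1.00 log units; beyond the scatter) was seen. That step replaced the whole side chain together with its linking atom, so it bears on the present change only loosely, as a sign that this part of the molecule can move the read-out by a modest amount. Nothing measured addresses a methyl on the saturated ring or the shifted point of attachment. The step of a 1.7-fold lower number from compound 2 to compound 3 (0.22 log units; within the scatter) is therefore expected to be small and of uncertain direction. Compound 3 is estimated at 150 nM, within 40 nM to 600 nM.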

Compound 3, half-maximal effective concentration: 65 nM
For compound 3 the middle estimate is 2.3-fold (0.36 log units) above the measured one; the measured number falls inside the stated range.
By their numbers in this assay, from the lowest: compound 1; then compound 3; then compound 2.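

In this assay, the change of piperidin-3-yl to 3-methylpiperidin-4-yl gives a 3.8-fold lower number from compound 2 to compound 3 (0.59 log units; beyond the scatter) with the oxygen on the aromatic ring kept in place. The earlier step, a 10-fold higher number from compound 1 to compound 2 (1.00 log units; beyond the scatter) and nothing finer, had replaced the side chain together with its linking atom, whereas this one shows that the saturated ring alone can move the read-out beyond the scatter. Even so, the ether does not fully return to the level of the carbon-linked morpholine side chain, as a 2.6-fold higher number from compound 1 to compound 3 (0.41 log units; beyond the scatter) shows, and nothing available here explains either shift.

Going by these compounds, the new group carries both a methyl and a shifted point of attachment, so it remains open how much of the step belongs to each, and plain piperidin-4-yl on the same oxygen would separate the two. Also open, on these data alone, is how the read-out would respond to 3-ethylpiperidin-4-yl, a larger group at the same ring carbon, or to the opposite arrangement at the two defined stereocentres.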